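Working notes on cytotoxicity in the series: the ethyl analogue

The source may hold more compounds than are shown below. What is called first, only, known or untested is meant among the compounds shown, and "the series" means these compounds.

Measured compounds:
compound 1 `O=c1[nH]c(=S)ccn1[C@H]1C[C@H](F)[C@@H](CO)O1` — > 100 ug/mL
compound 2 `O=c1[nH]c(=O)n([C@H]2C[C@H](F)[C@@H](CO)O2)cc1C(F)(F)F` — > 100 ug/mL

Of the compounds shown here, two have been tested in an ADME assay on Huh-7 cells (Homo sapiens) for cytotoxicity, read by XTT assay, with a stated time of 2 days; a higher number here means that more compound is tolerated, a lower number that less compound is tolerated. Compound 1 `O=c1[nH]c(=S)ccn1[C@H]1C[C@H](F)[C@@H](CO)O1` gives only a limit in this assay, > 100 ug/mL, not a number. Compound 2 `O=c1[nH]c(=O)n([C@H]2C[C@H](F)[C@@H](CO)O2)cc1C(F)(F)F` likewise gives only a limit in this assay, > 100 ug/mL. Where compound 2 stands is thus known only as the limit of > 100 ug/mL in this assay, at which 2 of the 2 values shown sit. For the measured compounds named here, no step between measured compounds can be drawn from two limits, and of this pair one can say only that both values sit at the limit.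

Compound 3 `CCc1cn([C@H]2C[C@H](F)[C@@H](CO)O2)c(=O)[nH]c1=O` is the next to be measured. It differs from compound 2 by ethyl in place of trifluoromethyl on an aromatic carbon. Going by the values given here, no measured step shows what this exchange does in this assay. With both measured values sitting at the limit, no step beyond the scatter is expected in either direction. Compound 3 is expected to give 120 ug/mL in this assay, with a range from 50 ug/mL to 300 ug/mL, most probably reported again as a limit. The estimated step that the limit leaves unreadable from compound 2 to compound 3 is accordingly none beyond the scatter.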

Compound 3, half-maximal cytotoxic concentration: > 200 ug/mL
Compound 3 ended at the assay's limit; the forecaster's own chance of this, stated with the estimate: 80%; middle value at least 1.6-fold (0.22 log units) from the limit.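

In this assay compound 3 gives only a limit, > 200 ug/mL. Compound 2 also gives only a limit, > 100 ug/mL. For the compounds shown here, no step between compound 2 and compound 3 can be read for ethyl in place of trifluoromethyl on an aromatic carbon. The compounds shown leave open at what concentration any of them becomes cytotoxic to these cells.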